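Indolyl and benzimidazolyl variants of a diphenylmethylpiperazine series

The source may hold more compounds than are shown below. What is called first, only, known or untested is meant among the compounds shown, and "the series" means these compounds.

Measured so far:
compound 1 `Cc1cc2ncn(CCCCN3CCN(C(c4ccccc4)c4ccccc4)CC3)c2cc1C`: 770 nM
compound 2 `Cc1cccc2c1ccn2CCCCN1CCN(C(c2ccccc2)c2ccccc2)CC1`: 5300 nM
compound 3 `COc1ccc2c(ccn2CCCCN2CCN(C(c3ccccc3)c3ccccc3)CC2)c1`: > 10000 nM

In an assay on RPMI-8226 cells for antagonist activity at P2X purinoceptor 7 (Homo sapiens), read by calcium flux (a lower number here means a stronger inhibitor, a higher number a weaker inhibitor), compound 1 gives 770 nM. Compound 2 gives 5300 nM in this assay, a change of a 6.9-fold higher number from compound 1 to compound 2 (0.84 log units; beyond the scatter). For compound 3 this assay reports only a limit, > 10000 nM; this is the limit of > 10000 nM in this assay, at which 1 of the 3 values shown sits. From compound 1 the step is an at least 12-fold higher number from compound 1 to compound 3 (1.11 log units; beyond the scatter), and from compound 2 it is an at least 1.8-fold higher number from compound 2 to compound 3 (0.27 log units; that floor lies within the scatter), so compound 3 stands no better than compound 2 and clearly behind compound 1.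

Compound 4 `Fc1ccc2ccn(CCCCN3CCN(C(c4ccccc4)c4ccccc4)CC3)c2c1` is not yet measured. It differs from compound 3 by 6-fluoro-1H-indol-1-yl in place of 5-methoxy-1H-indol-1-yl on a saturated chain carbon, four bonds along the chain from an amine nitrogen in a ring. Within the data shown here, the two steps that bear on it, the one from compound 1 to compound 2 and the one from compound 2 to compound 3, both run toward weaker values, and the second stays within the scatter. A change within the indolyl group alone is therefore expected to give a step of about an at least 1.2-fold lower number from compound 3 to compound 4 (0.09 log units; that floor lies within the scatter), near the limit, with no clear direction. Compound 4 is estimated at 8000 nM, between 3000 nM and 30000 nM.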

Compound 4, half-maximal inhibitory concentration: 110 nM
Beside the measured number, compound 4's estimate is 73-fold (1.86 log units) above it; measured number below the stated range.
By their numbers in this assay, from the lowest: compound 4; then compound 1; then compound 2. At a limit, above all of these: compound 3.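

In this assay, an indolyl group at this place on the saturated chain carbon is not tied to weak values: 6-fluoro-1H-indol-1-yl in place of 5-methoxy-1H-indol-1-yl gives an at least 90-fold lower number from compound 3 to compound 4 (1.95 log units; beyond the scatter), and the comparison with the other indolyl group gives a 48-fold lower number from compound 2 to compound 4 (1.68 log units; beyond the scatter). The earlier lead of the 5,6-dimethyl-1H-benzimidazol-1-yl group over the indolyl groups does not hold for this one, which gives a 7.0-fold lower number from compound 1 to compound 4 (0.85 log units; beyond the scatter), so the substituent on the indolyl group matters as well as the choice between the two ring types. The value of compound 3 is a limit: the limit of > 10000 nM in this assay, at which 1 of the 4 values shown sits.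

Open, as far as these compounds go, is whether 5-fluoro-1H-indol-1-yl or 6-chloro-1H-indol-1-yl would match the group of compound 4. Also open, from the compounds shown here alone, is whether a longer chain to the amine nitrogen would keep this strength.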